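A few compounds are considered here, and "the series" means these few. Any claim that something is new, unique, unknown or untested is made for them only; others in the source may bear on it.

Measured compounds:

Compound 1: `O=C(O)CCCCCOc1cc(-c2ccccc2)cc(-c2ccc(F)cc2)n1`, in an assay on cell membranes from spleen (Cavia porcellus) for binding affinity to leukotriene B4 receptor 1 (Homo sapiens) (on this read-out lower numbers stand for stronger inhibition and higher numbers for weaker inhibition), compound 1 gives 30 nM
Compound 2: `Cc1ccc(-c2cc(-c3ccccc3)cc(OCCCCCC(=O)O)n2)cc1`, in this assay compound 2 gives 300 nM

Compound 2 stands at the higher of the two numbers, so its binding is the weaker of the pair. Within the data shown here, the only measured step joining them is a 10-fold higher number from compound 1 to compound 2 (1.00 log units; beyond the scatter), a change on the outer phenyl ring.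

Compound 3, `COc1ccc(-c2cc(-c3ccccc3)cc(OCCCCCC(=O)O)n2)cc1`, keeps the shared core and chain and differs from compound 2 in one place: methoxy in place of methyl on an aromatic carbon. Among the measured compounds shown here, no measured step shows what a methoxy group does here; the one step on record concerns fluoro against methyl and says nothing about an added oxygen at the same place. The expectation is therefore a step of about no change at the digits printed from compound 2 to compound 3 (within the scatter), within the scatter. Compound 3 is estimated to give 300 nM in this assay, with a plausible range from 100 nM to 1000 nM.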

Compound 3, half-maximal inhibitory concentration: 1000 nM
The estimate for compound 3 lay 3.3-fold (0.52 log units) below the measured number, and the stated range covers the measured number.
By their numbers in this assay, from the lowest: compound 1; then compound 2; then compound 3.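

Replacing methyl with methoxy on this aromatic carbon, para to a large group, gives in this assay a 3.3-fold higher number from compound 2 to compound 3 (0.52 log units; beyond the scatter) and shows that the position responds to more than the fluoro-to-methyl change. Measured against the fluoro compound, the change is larger, with a 33-fold higher number from compound 1 to compound 3 (1.52 log units; beyond the scatter) on record for methoxy in place of fluoro. From the lowest number to the highest, the three groups now run fluoro, methyl, methoxy, but no measurement here accounts for that order.

From the compounds shown here alone, whether a chlorine atom, a hydroxyl or an amine on this carbon would fit that order remains open. Going by these compounds, it is also open whether the order would hold with a longer chain carrying the carboxylic acid.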